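Replacing 1,3-thiazol-5-yl with cyclobutyl on a shared core

The compounds below may be only part of what the source reports. "The series", "measured", "known", "first", "only" and "open" are said of these compounds alone.

Compound 1 `CCCS(=O)(=O)Nc1ccc2c(c1)S(=O)(=O)N=C(c1c(O)c(-c3cccs3)nn(CCC(C)C)c1=O)N2`: > 1000 nM
Compound 2 `CC(C)CCn1nc(-c2cncs2)c(O)c(C2=NS(=O)(=O)c3cc(NS(C)(=O)=O)ccc3N2)c1=O`: > 33000 nM

Both entries come from an ADME assay on Huh-7 cells (Homo sapiens) for cytotoxicity, with a stated time of 72 h (a lower number here means that less compound is tolerated, a higher number that more compound is tolerated), and neither is a true number. Compound 1 reads > 1000 nM, which is a limit of the assay. Compound 2 reads > 33000 nM, which is also a limit of the assay. Going by the values given here, compound 2 therefore has no exact position on the scale, and its only neighbour here is another limit.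

Compound 3 `CC(C)CCn1nc(C2CCC2)c(O)c(C2=NS(=O)(=O)c3cc(NS(C)(=O)=O)ccc3N2)c1=O` differs from compound 2 in one place, with cyclobutyl in place of 1,3-thiazol-5-yl on an aromatic carbon. Among the compounds with values here, no measured pair of compounds shows what a single change does in this assay, so no size of step can be read from the data. The expectation rests on compound 2 and its limit of > 33000 nM. No change beyond the usual scatter is expected, and neither direction is favoured. The expected step of an at least 1.1-fold lower number from compound 2 to compound 3 (0.04 log units; that floor lies within the scatter) is correspondingly small. Another limit, rather than a number, is also expected to be a likely result. For compound 3 the estimate is 30000 nM, with an expected range of 10000 nM to 100000 nM.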

Compound 3, half-maximal cytotoxic concentration: > 33000 nM
Compound 3 ended at the assay's limit; the forecaster's own chance of this, stated with the estimate: 75%; middle value at least 1.1-fold (0.04 log units) away from the limit.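

In this assay compound 2 reads > 33000 nM, which is a limit of the assay. Going by these compounds alone, compound 3 reads > 33000 nM, also a limit, so no step between compound 2 and compound 3 can be read. Still open, going by these compounds, is the concentration at which either compound becomes toxic to the cells, and whether cyclobutyl in place of 1,3-thiazol-5-yl shifts it.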